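Cyclohexyl for 3,4-difluorophenyl on the amine nitrogen

A few compounds are considered here, and "the series" means these few. Any claim that something is new, unique, unknown or untested is made for them only; others in the source may bear on it.

Among the compounds with values here, compound 2 `Cc1ccc(S(=O)(=O)/N=C(/CCNC2=CC(=O)c3ccccc3C2=O)Nc2ccc(F)c(F)c2)cc1` gives 12900 nM in a functional assay on DU-145 cells (Homo sapiens) for cytotoxicity, read by MTT assay, with a stated time of 48 h (a lower number here means a stronger inhibitor, a higher number a weaker inhibitor), the lowest of the two numbers so far; compound 1 `Cc1ccc(S(=O)(=O)/N=C(/CCNC2=CC(=O)c3ccccc3C2=O)Nc2cccc(C(F)(F)F)c2)cc1` gives 84100 nM, and the step of a 6.5-fold lower number from compound 1 to compound 2 (0.81 log units; beyond the scatter) is the only measured one. Compound 3 `Cc1ccc(S(=O)(=O)/N=C(/CCNC2=CC(=O)c3ccccc3C2=O)NC2CCCCC2)cc1` carries cyclohexyl in place of 3,4-difluorophenyl on an amine nitrogen. Within the data shown here, no measured step exchanges an aromatic ring for a non-aromatic one, so the step from compound 1 to compound 2 gives a sense of scale only; the direction remains open. For compound 3 a step of a 2.3-fold higher number from compound 2 to compound 3 (0.37 log units; beyond the scatter) toward a weaker inhibitor is expected. Compound 3 is estimated at 30000 nM, range 9000 nM to 100000 nM.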

Compound 3, half-maximal inhibitory concentration: 16600 nM
For compound 3 the middle estimate is 1.8-fold (0.26 log units) above the measured one, and the stated range covers the measured number.
By their numbers in this assay, from the lowest: compounds 2 and 3 (each within the scatter of the next); then compound 1.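

Exchanging the aromatic ring for a non-aromatic one on the amine nitrogen gives in this assay a 1.3-fold higher number from compound 2 to compound 3 (0.11 log units; within the scatter) so among the compounds shown, an aromatic ring is not required there to reach this level. Cyclohexyl in place of 3-(trifluoromethyl)phenyl gives a 5.1-fold lower number from compound 1 to compound 3 (0.70 log units; beyond the scatter) so the higher number of compound 1 does not follow aromatic rings as a class. No evidence bearing on the cause of either step is available.

Open, as far as these compounds go, is how an n-butyl chain, or a cyclohexyl ring carrying an amine or a carboxylic acid, would read at this nitrogen.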